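Swapping the ring on the thiocarbonyl carbon

A few compounds are considered here, and "the series" means these few. Any claim that something is new, unique, unknown or untested is made for them only; others in the source may bear on it.

Among the measured compounds shown here, compound 1 `Cc1cccc(/C(N)=N/NC(=S)N2CCSCC2)n1` is one of two compounds measured in a functional assay on A-375 cells (Homo sapiens) for cytotoxicity, read by MTT assay, with a stated time of 72 h, tested at 100 uM (on this read-out lower numbers stand for less inhibition of growth and higher numbers for more inhibition of growth at the one concentration tested), where compound 1 gives 77.4%. The other, compound 2 `N/C(=N\NC(=S)N1CCSCC1)c1ccccn1`, gives 87.8% in this assay, so compound 1 stands lowest of the two, and the step of a number 10.4 percentage points higher from compound 1 to compound 2 (beyond the scatter) lies beyond the scatter. That step exchanges hydrogen for methyl on an aromatic carbon, far from the thiocarbonyl side of the shared core.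

Compound 3 `Cc1cccc(/C(N)=N/NC(=S)N2CCCC2)n1` has not yet been measured. It differs from compound 1 by pyrrolidin-1-yl in place of thiomorpholin-4-yl on a thiocarbonyl carbon. For the measured compounds named here, no measured step touches this part of the molecule: the only step on record, a number 10.4 percentage points higher from compound 1 to compound 2 (beyond the scatter), concerns the aromatic methyl, so it gives no direct guide to what the ring exchange will do in this assay. With nothing pointing either way, the expectation is a step from compound 1 to compound 3 of about a number 2.4 percentage points lower from compound 1 to compound 3 (within the scatter), that is, none beyond the scatter. Compound 3 is therefore estimated to give 75% in this assay, within a range from 55% to 92%.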

Compound 3, percent growth inhibition at one concentration: 66.3%
The estimate for compound 3 lay 8.7 percentage points above the measured number; low and high end bracket the measured number.
By their numbers in this assay, from the lowest: compound 3; then compound 1; then compound 2.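

Among the compounds shown here, this is the first reading of the ring on the thiocarbonyl carbon, and it shows that this part of the molecule also matters in this assay: pyrrolidin-1-yl in place of thiomorpholin-4-yl brings a number 11.1 percentage points lower from compound 1 to compound 3 (beyond the scatter). The earlier step, a number 10.4 percentage points higher from compound 1 to compound 2 (beyond the scatter), concerned only the aromatic methyl, so two separate places on the shared core have now each given a step beyond the scatter, while this single exchange swaps a six-membered ring holding sulfur for a five-membered ring without it and so changes ring size and ring atoms together. Nothing available explains why the number moves this way.

Still open, from the compounds shown here alone, is which of those two differences carries the step: piperidin-1-yl, a six-membered ring with carbon in place of the sulfur, would separate them, and morpholin-4-yl, with oxygen in that place, would add a further comparison. Also open, going by these compounds, is whether a ring is needed here at all, which an open-chain dimethylamino group on the thiocarbonyl carbon would address.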